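Swapping the phenyl substituent on the piperidine ether

This account rests on a few compounds, and the source may have more. Where it says the series, first, only, none or still open, it means among the compounds named here.

Of the compounds shown here, three sharing one core have been measured in an assay on microsomes from liver for inhibition of acyl-CoA desaturase 1 (Rattus norvegicus); on this read-out higher numbers stand for weaker inhibition and lower numbers for stronger inhibition. Compound 1 `Cc1ccc(OC2CCN(c3ccc(-n4ccnc4)nn3)CC2)cc1` gives 527 nM, the highest of the three numbers. Compound 2 `OCc1nnc(-c2ccc(N3CCC(Oc4ccccc4C(F)(F)F)CC3)nn2)s1` gives 3.2 nM, and compound 3 `FC(F)(F)c1ccccc1OC1CCN(c2ccc(-n3ccnc3)nn2)CC1` gives 4 nM. Among the measured compounds shown here, the only step between two compounds that differ in one place is a 1.3-fold higher number from compound 2 to compound 3 (0.10 log units; within the scatter), a change on the far end of the molecule that leaves the number essentially unchanged. Compound 1 and compound 3 differ in the group attached to the ether oxygen, and their two values stand far apart, with compound 3 much lower.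

Compound 4 `Brc1cccc(OC2CCN(c3ccc(-n4ccnc4)nn3)CC2)c1` has not yet been measured. It differs from compound 1 by 3-bromophenyl in place of 4-methylphenyl on an oxygen on a saturated carbon. For the measured compounds named here, no measured step covers this exact exchange; the step from compound 2 to compound 3 concerns a different part of the molecule and says nothing about the phenyl ring. Going by the values given here, what can be drawn on is only that compound 1, with its 4-methylphenyl, sits high, while compound 3, carrying a different substituted phenoxy, sits low. A change of the phenyl substituent is therefore expected to move the number downward, estimated as a 4.4-fold lower number from compound 1 to compound 4 (0.64 log units; beyond the scatter). For compound 4 the expected value in this assay is 120 nM, with a range from 25 nM to 500 nM.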

Compound 4, half-maximal inhibitory concentration: 23 nM
Compound 4: middle estimate off by 5.2-fold (0.72 log units), on the high side; measured number outside the range, below it.
By their numbers in this assay, from the lowest: compounds 2 and 3 (each within the scatter of the next); then compound 4; then compound 1.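

In this assay, the phenyl group on this oxygen proves to matter strongly on its own: with the rest of the molecule unchanged, 3-bromophenyl in place of 4-methylphenyl gives a 23-fold lower number from compound 1 to compound 4 (1.36 log units; beyond the scatter). Among the compounds shown here, that is the first measured step at this position, and it contrasts with the step at the far end of the molecule, a 1.3-fold higher number from compound 2 to compound 3 (0.10 log units; within the scatter), which stays within the scatter. The two groups match in what can be counted, with 7 heavy atoms each, one aromatic ring and no hydrogen-bond donors or acceptors, and no measurement shown here explains why the exchange moves the number so far.

The exchange changes both the substituent and its place on the ring, so the compounds shown leave open which of the two drives the step; 3-methylphenyl and 4-bromophenyl would separate them. Also open, from the compounds shown here alone, are how an unsubstituted phenyl or a 3-methoxyphenyl would compare, and whether 5-(hydroxymethyl)-1,3,4-thiadiazol-2-yl in place of 1H-imidazol-1-yl would leave the number of compound 4 as little changed as it does between the pair already measured.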